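The source may hold more compounds than are shown below. What is called first, only, known or untested is meant among the compounds shown, and "the series" means these compounds.

Going by the values given here, compound 2, `COc1ccc(N2CCN(Cc3csc(N)c3C(=O)c3ccc(Cl)cc3)CC2)cc1`, gives in a functional assay on CHO cells with adenosine receptor A1 (Homo sapiens) as the target, read by cAMP accumulation and immunoassay, with a stated time of 6 min, tested at 0.1 uM (on this read-out higher numbers stand for a weaker effect at the one concentration tested and lower numbers for a stronger effect), a value of 0%, the lowest of the two numbers measured so far; compound 1, `Nc1scc(CN2CCN(c3cccc(Cl)c3Cl)CC2)c1C(=O)c1ccc(Cl)cc1`, stands nearest with 3.2%, and the step of a number 3.2 percentage points lower from compound 1 to compound 2 (within the scatter) lies within the scatter, so the two cannot be told apart. Compound 3, `Nc1scc(CN2CCN(c3ccccc3C(F)(F)F)CC2)c1C(=O)c1ccc(Cl)cc1`, differs from compound 2 in one place: 2-(trifluoromethyl)phenyl in place of 4-methoxyphenyl on an amine nitrogen in a ring. Among the compounds with values here, the only measured step that bears on this change is the one on the same ring nitrogen, a number 3.2 percentage points lower from compound 1 to compound 2 (within the scatter), which is within the scatter, so exchanging one aryl group for another at that position has so far made no difference that can be trusted. On that single comparison, compound 3 is expected to show no step beyond the scatter, an expected step of a number 3 percentage points higher from compound 2 to compound 3 (within the scatter). Compound 3 is therefore estimated at 3%, between 0% and 15%.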

Compound 3, a percentage reported as activity, at one concentration (the size of the read-out at that concentration, not a potency): -7.5%
For compound 3 the middle estimate is 10.5 percentage points above the measured one; the measured number lies below the stated range.
By their numbers in this assay, from the lowest: compounds 3, 2 and 1 (each within the scatter of the next, the first and the last beyond it).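

At this ring nitrogen, the choice of aryl group now gives its first step beyond the scatter in this assay: a modest move towards a stronger effect, a number 10.7 percentage points lower from compound 1 to compound 3 (beyond the scatter), when 2-(trifluoromethyl)phenyl replaces 2,3-dichlorophenyl. Replacing 4-methoxyphenyl with the same group gives a number 7.5 percentage points lower from compound 2 to compound 3 (within the scatter), so that change alone cannot be trusted, and among these three compounds only the pair with the widest gap can be told apart. Nothing measured here explains why these aryl groups differ.

On these data alone, it remains open whether an aryl group is needed on this nitrogen at all, or whether a pyridine ring, a plain methyl group or a longer alkyl chain would serve there. The compounds shown also leave open how a carboxylic acid or an amine on the aryl ring would affect the read-out.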